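Fluoromethyl for hydroxymethyl in a dihydroxy diarylbutane series

The source may hold more compounds than are shown below. What is called first, only, known or untested is meant among the compounds shown, and "the series" means these compounds.

Measured compounds:
- compound 1, `COc1cc(C(c2ccc(O)c(OC)c2)[C@@H](CO)C(C)C)ccc1O`: > 100000 nM
- compound 2, `COc1ccc(C(c2ccc(OC)c(OC)c2)[C@@H](C)[C@@H](C)CO)cc1OC`: > 100000 nM

In a functional assay on HeLa cells (Homo sapiens) for cytotoxicity, read by WST assay, with a stated time of 48 h (on this read-out lower numbers stand for stronger inhibition and higher numbers for weaker inhibition), compound 1 gives > 100000 nM, which is a limit of the assay and not a number. Compound 2 likewise gives > 100000 nM in this assay, again a limit. Going by the values given here, both values therefore stand at the limit of > 100000 nM in this assay, at which 2 of the 2 values shown sit, and no step between measured compounds is available.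

Compound 3, `COc1cc(C(c2ccc(O)c(OC)c2)[C@H](C)[C@H](C)CF)ccc1O`, differs from compound 1 by 2-(fluoromethyl)-1-methylpropyl in place of 1-(hydroxymethyl)-2-methylpropyl on a saturated chain carbon bound to two aromatic carbons. With both known values sitting at the limit, no basis exists for a step beyond the scatter, and compound 3 is expected to remain at or near that limit, giving an expected step that the limit leaves unreadable from compound 1 to compound 3. The estimated value for compound 3 in this assay is 150000 nM, in the range 70000 nM to 400000 nM.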

Compound 3, half-maximal inhibitory concentration: 75000 nM
Compound 3: the middle estimate sits 2.0-fold (0.30 log units) above what was measured; the measured number falls inside the stated range.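

In this assay, going by these compounds alone, compound 3 gives 75000 nM, the first value in this set that is a number and not a limit. Placing 2-(fluoromethyl)-1-methylpropyl where 1-(hydroxymethyl)-2-methylpropyl stood on a saturated chain carbon bound to two aromatic carbons gives an at least 1.3-fold lower number from compound 1 to compound 3 (0.12 log units; that floor lies within the scatter), so no gain beyond the scatter can be claimed for this change. The other compounds remain uninformative on size: the limit of > 100000 nM in this assay, at which 2 of the 3 values shown sit.

Open, going by these compounds, is whether the fluorine or the altered chain accounts for the number seen with compound 3. Also open, on these data alone, is how an amine or a carboxylic acid at the end of this chain would read.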